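Fluorine Added Where Two Inactive Compounds Meet

A few compounds are considered here, and "the series" means these few. Any claim that something is new, unique, unknown or untested is made for them only; others in the source may bear on it.

Two compounds open the account. Compound 1 `Fc1ccc(NC(=S)Nc2nc3ccccc3s2)cc1` was tested in a functional assay on B16-F10 cells (Mus musculus) for cytotoxicity, read by MTT assay, with a stated time of 48 h (a higher number here means a weaker inhibitor, a lower number a stronger inhibitor), and compound 1 gives > 50000 nM, which is a limit of the assay and not a number. Compound 2 `Cc1ccc2nc(NC(=S)Nc3ccccc3)sc2c1` was tested in this assay as well, and compound 2 gives > 50000 nM, likewise a limit rather than a measured value. Going by the values given here, compound 2 therefore stands at the limit described by the limit of > 50000 nM in this assay, at which 2 of the 2 values shown sit, and no step between measured compounds can be drawn from these two entries. The unmeasured compound 3 `Cc1ccc2nc(NC(=S)Nc3ccc(F)cc3)sc2c1` differs from compound 2 in one place: fluoro in place of hydrogen on an aromatic carbon. Compound 1 carries the same fluoro group on its own core and also sits at the limit, so the expected step that the limit leaves unreadable from compound 2 to compound 3 in this assay is none beyond the scatter. Compound 3 is accordingly estimated at 80000 nM, with a range from 30000 nM to 250000 nM, and is expected most likely to be reported again only as a limit.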

Compound 3, half-maximal inhibitory concentration: > 50000 nM
Compound 3: a limit, no number (the forecaster's own chance of this, stated with the estimate: 80%); the middle value lies beyond the limit too.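

Going by these compounds alone, no step from compound 2 to compound 3, or from compound 1 to compound 3, can be read in this assay because each compound gives only a limit, not a number: the limit of > 50000 nM in this assay, at which 3 of the 3 values shown sit.

Going by these compounds, whether fluoro or methyl in place of hydrogen changes potency at all in this assay stays open.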